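Methyl in place of hydrogen on two cores

The source may hold more compounds than are shown below. What is called first, only, known or untested is meant among the compounds shown, and "the series" means these compounds.

Measured compounds:
Compound 1, `CCC1(C)CCOC1=O`. In a functional assay on the whole organism with Mus musculus as the target, in the maximal electroshock model (on this read-out higher numbers stand for an effect only at larger amounts of compound and lower numbers for an effect already at smaller amounts), compound 1 gives > 500 mg/kg, which is a limit of the assay.
Compound 2, `CCC1(CC)CCOC1=O`. In this assay compound 2 gives 463 mg/kg.
Compound 3, `CC(C)C1CCSC1=O`. In this assay compound 3 gives > 500 mg/kg, which is a limit of the assay.

Among the measured compounds shown here, the one measured step is methyl in place of hydrogen on a saturated chain carbon bound to a saturated ring carbon, giving an at least 1.0-fold lower number from compound 1 to compound 2 (0.03 log units; that floor lies within the scatter). How the core of compound 3 differs from the core of compound 1 is not broken down here.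

Compound 4, `CC(C)(C)C1CCSC1=O`, is not yet measured. It differs from compound 3 by methyl in place of hydrogen on a saturated chain carbon bound to two saturated chain carbons and a saturated ring carbon. This is the same kind of change as from compound 1 to compound 2, but the place differs: here the chain carbon is bound to two saturated chain carbons and a saturated ring carbon, there to a saturated ring carbon only.

For compound 4 in this assay the expected step is a step that the limit leaves unreadable from compound 3 to compound 4, resting on an at least 1.0-fold lower number from compound 1 to compound 2 (0.03 log units; that floor lies within the scatter) and on the fact that compound 3 sits at the limit of > 500 mg/kg in this assay, at which 2 of the 3 values shown sit. The number itself may well again be only a limit. The estimate for compound 4 in this assay is 550 mg/kg, with a range from 350 mg/kg to 1000 mg/kg.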

Compound 4, dose for half-maximal effect: > 500 mg/kg
Compound 4: only a limit was reported; the forecaster's own chance of this, stated with the estimate: 70%; the middle value is on the limit's open side.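

In this assay compound 4 gives > 500 mg/kg, which is a limit of the assay. Compound 3 also stands at a limit, so no step can be read between compound 3 and compound 4: the limit of > 500 mg/kg in this assay, at which 3 of the 4 values shown sit.

The compounds shown leave open whether this methyl in place of hydrogen changes the read-out at all on this core.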